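A few compounds are considered here, and "the series" means these few. Any claim that something is new, unique, unknown or untested is made for them only; others in the source may bear on it.

Working notes on the series. Compound 1 `CN(C)c1nc(N)c2ncn([C@@H]3C[C@@H](O)[C@H](CO)O3)c2n1` in a functional assay on PHA-Ly cells (Homo sapiens) (on this read-out lower numbers stand for stronger inhibition and higher numbers for weaker inhibition), gives only a limit of the assay, > 300 uM; this reading is the limit of > 300 uM in this assay, at which 1 of the 2 values shown sits. Compound 2 `CSc1nc(SC)c2ncn([C@@H]3C[C@@H](O)[C@H](CO)O3)c2n1` in this assay gives 167 uM, the one numerical reading among the two shown. Compound 3 `CNc1nc(SC)nc2c1ncn2[C@@H]1C[C@@H](O)[C@H](CO)O1` has not yet been measured; it differs from compound 2 by methylamino in place of methylsulfanyl on an aromatic carbon. Among the measured compounds shown here, no pair of measured compounds shows this change on its own, so no measured step can guide it; the two measured compounds differ at more than one place and show only that compound 1 is a limit while compound 2 is a number. For this assay the expected step is small, likely within the scatter, and is taken as a 1.2-fold higher number from compound 2 to compound 3 (0.08 log units; within the scatter). Compound 3 is estimated at 200 uM, within a range from 60 uM to 600 uM, with a real chance that only a limit is reported.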

Compound 3, concentration for 50% inhibition: 81 uM
Compound 3: middle estimate off by 2.5-fold (0.39 log units), on the high side, and the stated range covers the measured number.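

In this assay, among the compounds shown here, methylamino in place of methylsulfanyl on this aromatic carbon gives a 2.1-fold lower number from compound 2 to compound 3 (0.31 log units; beyond the scatter), the first step that can be read at this position, and it lies beyond the scatter though it is modest. The change brings in a hydrogen-bond donor where the leaving group has none, but a single pair cannot tie the step to that donor. For the compounds shown here, nothing measured so far bears on the cause of this step.

Going by these compounds, it remains open whether a plain amine or a longer chain such as ethylamino at this position would extend the step. On these data alone, it is also open whether the same change at the methylsulfanyl group remaining in compound 3 would act alike, and compound 1, a limit of the assay at > 300 uM, does not settle this.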